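This account rests on a few compounds, and the source may have more. Where it says the series, first, only, none or still open, it means among the compounds named here.

Compound 1 `O=C(NOCc1ccccc1)c1cn(-c2ccccc2)nc1-c1ccccc1` carries a benzyloxy group on the amide; in a functional assay on HeLa cells (Homo sapiens) for antiproliferative activity, read by MTT assay, with a stated time of 48 h, in the presence of a further agent that is not named here (on this read-out lower numbers stand for stronger inhibition of growth and higher numbers for weaker inhibition of growth), compound 1 gives 8830 nM. Compound 2 `O=C(NOCc1ccccc1Cl)c1cn(-c2ccccc2)nc1-c1ccccc1` differs from it by chloro in place of hydrogen on an aromatic carbon and in this assay compound 2 gives 17800 nM, which is a 2.0-fold higher number from compound 1 to compound 2 (0.30 log units; within the scatter). Compound 3 `COc1ccc(-c2nn(-c3ccccc3)cc2C(=O)NOCc2ccccc2Cl)cc1` keeps the (2-chlorobenzyl)oxy group on a core whose difference from that of compound 1 is not broken down here; in this assay compound 3 gives 3480 nM, reached through a 5.1-fold lower number from compound 2 to compound 3 (0.71 log units; beyond the scatter). Compound 4 `COc1ccc(-c2nn(-c3ccccc3)cc2C(=O)NOCc2ccc(Cl)cc2Cl)cc1` differs from compound 3 by chloro in place of hydrogen on an aromatic carbon. This is the same kind of change as that between compound 1 and compound 2, though the place differs: there the chloro sat ortho to a large group, here it sits meta to a chloro group and para to a large group. Because the earlier step read a 2.0-fold higher number from compound 1 to compound 2 (0.30 log units; within the scatter), little movement is expected. The expected step is therefore a 1.3-fold higher number from compound 3 to compound 4 (0.11 log units; within the scatter). In this assay compound 4 is estimated at 4500 nM, with a range from 1500 nM to 12000 nM.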

Compound 4, concentration for 50% growth inhibition: 5750 nM
Beside the measured number, compound 4's estimate is 1.3-fold (0.11 log units) below it; the range from low to high includes it.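

In this assay, chloro in place of hydrogen on an aromatic carbon gives a 1.7-fold higher number from compound 3 to compound 4 (0.22 log units; within the scatter). Set beside the earlier case, the change reads alike on the two cores, with no difference beyond the scatter: the same change on two cores in this assay, a 2.0-fold higher number (0.30 log units; within the scatter) from compound 1 to compound 2 and a 1.7-fold higher number (0.22 log units; within the scatter) from compound 3 to compound 4, 1.2-fold (0.09 log units) apart, within the scatter of two such steps This does not show that the change would read the same on every core in the series, since only two cores are shown and the chloro enters at a different place in each step.

The compounds shown leave open how an amine or a carboxylic acid in place of the chloro would read in this assay. They also leave open whether the step would hold on a third core.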